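The source may report more compounds than this note shows. Statements on the series, on what has been measured and on what is new or still open speak of the compounds shown alone.

In a functional assay on Bel-7402 cells (Homo sapiens) for antiproliferative activity, read by MTT assay, with a stated time of 72 h (on this read-out lower numbers stand for stronger inhibition and higher numbers for weaker inhibition), compound 3 `COc1cccc(CNCc2c(C(=O)O)n(Cc3ccccc3)c3cc(C)ccc23)c1` gives 12500 nM, within the scatter of compound 1 `COc1cccc(CNCc2c(C(=O)O)n(Cc3ccc(O)cc3)c3cc(C(C)C)ccc23)c1` at 7080 nM. Compound 2 `COc1cccc(CNCc2c(C(=O)O)n(Cc3ccc(O)cc3)c3ccccc23)c1` gives > 50000 nM, which is a limit of the assay and not a number. Compound 4 `COc1cccc(CNCc2c(C(=O)O)n(Cc3ccc(O)cc3)c3cc(C)ccc23)c1` differs from compound 3 by hydroxy in place of hydrogen on an aromatic carbon, benzyl to 4-hydroxybenzyl (hydroxy in place of hydrogen on an aromatic carbon). Among the compounds with values here, no measured step makes this exchange on its own. Within the data shown here, the one measured step, an at least 7.0-fold higher number from compound 1 to compound 2 (0.84 log units; beyond the scatter), is hydrogen in place of isopropyl among 4-hydroxybenzyl compounds, a change elsewhere in the molecule, so it bears only indirectly. No step beyond the scatter is therefore expected in this assay, and the estimated step is a 1.1-fold higher number from compound 3 to compound 4 (0.05 log units; within the scatter). For compound 4 the expected value is 14000 nM, with an estimated range from 6000 nM to 40000 nM.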

Compound 4, half-maximal inhibitory concentration: > 50000 nM
Compound 4: a limit, no number; the forecaster's own chance of this, stated with the estimate: 15%; middle value at least 3.5-fold (0.55 log units) from the limit.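

In this assay, the exchange of benzyl for 4-hydroxybenzyl now has a measured step of its own, an at least 4.0-fold higher number from compound 3 to compound 4 (0.60 log units; beyond the scatter), so hydroxy on this aromatic carbon, para to a large group, is not neutral with methyl on the core. Among the 4-hydroxybenzyl compounds, methyl does not keep what isopropyl gives, an at least 7.0-fold higher number from compound 1 to compound 4 (0.84 log units; beyond the scatter). The step between compound 2 and compound 4 cannot be read, because both sit at one limit: the limit of > 50000 nM in this assay, at which 2 of the 4 values shown sit. Open, going by these compounds, is whether hydroxy costs as much alongside isopropyl, and how methoxy or an amine would fare at this place.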